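From Methoxy to Chloro: Expecting Compound 3

A few compounds are considered here, and "the series" means these few. Any claim that something is new, unique, unknown or untested is made for them only; others in the source may bear on it.

Of the compounds shown here, two sharing one core have been measured in a functional assay for agonist activity at Alpha-1A adrenergic receptor (Homo sapiens); on this read-out lower numbers stand for an effect already at smaller amounts and higher numbers for an effect only at larger amounts of compound. Compound 1 `CSc1ccc(C)cc1NCC1=NCCN1` gives 0.11 nM. Compound 2 `COc1ccc(SC)c(NCC2=NCCN2)c1` carries a methoxy group where compound 1 carries a methyl. Among the measured compounds shown here, compound 2 gives 1.59 nM and so stands at the higher of the two numbers; the single measured step, a 14-fold higher number from compound 1 to compound 2 (1.16 log units; beyond the scatter), shows that what sits at this position matters a great deal.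

Compound 3 `CSc1ccc(Cl)cc1NCC1=NCCN1` is not yet measured. It differs from compound 2 by chloro in place of methoxy on an aromatic carbon. For the measured compounds named here, no measured pair involves a chloro group, so the only guide is the change from compound 1 to compound 2, where methoxy brought one hydrogen-bond acceptor and the number rose sharply, while chloro, like methyl, brings none. Compound 3 is therefore expected to move back toward compound 1, by roughly a 4.0-fold lower number from compound 2 to compound 3 (0.60 log units; beyond the scatter). The estimate for compound 3 is 0.4 nM, within a range from 0.1 nM to 2 nM.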

Compound 3, half-maximal effective concentration: 0.437 nM
Estimate against measurement, compound 3: 1.1-fold (0.04 log units) below; low and high end bracket the measured number.
By their numbers in this assay, from the lowest: compound 1; then compound 3; then compound 2.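

In this assay, the position para to the methylsulfanyl group separates all three groups: replacing methoxy with chloro gives a 3.6-fold lower number from compound 2 to compound 3 (0.56 log units; beyond the scatter), yet replacing methyl with chloro gives a 4.0-fold higher number from compound 1 to compound 3 (0.60 log units; beyond the scatter), so chloro falls between the other two. Chloro, with 0 hydrogen-bond acceptors, shares that count with methyl but does not match its number, so the count of acceptors alone does not settle the result at this position. No measurement shown here explains why the three groups fall in this order.

Going by these compounds, what an amino group, a fluoro group or an ethyl chain would do at this position remains open. So does whether the same order of methyl, chloro and methoxy would hold with another group in place of the methylsulfanyl group.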